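Amino in place of hydrogen on the amide of compound 1

A few compounds are considered here, and "the series" means these few. Any claim that something is new, unique, unknown or untested is made for them only; others in the source may bear on it.

Compound 1 `NC(=O)c1ccc(NCc2nc(-c3ccccc3)nn2-c2ccccc2)cc1` stands lowest of the two measured compounds in an assay on Sf9 cells for inhibition of protein deacetylase HDAC6 (Homo sapiens), read by fluorescence, with a stated time of 40 min, tested at 100 nM (a lower number here means less inhibition, a higher number more inhibition at the concentration tested (going by the name of the read-out)), giving -4.4%. Compound 2 `CCc1ccc(-c2nc(CNc3ccc(C(=O)NO)cc3)n(-c3ccccc3)n2)cc1` gives 54.6% in this assay, a number well beyond the scatter above compound 1, though the two structures differ in several places. Compound 3 `NNC(=O)c1ccc(NCc2nc(-c3ccccc3)nn2-c2ccccc2)cc1` differs from compound 1 in one place: amino in place of hydrogen on an amide-type nitrogen. Among the compounds with values here, no measured pair shows this change, so the expected step from compound 1 to compound 3 is only a guess; a rise beyond the scatter is expected, a number 29.4 percentage points higher from compound 1 to compound 3 (beyond the scatter). Compound 3 is estimated at 25%, between -5% and 55%.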

Compound 3, a percentage reported as inhibition, at one concentration (the size of the read-out at that concentration, not a potency): 10%
For compound 3 the middle estimate is 15 percentage points above the measured one; measured number inside the range.
By their numbers in this assay, from the lowest: compound 1; then compound 3; then compound 2.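

In this assay, within the data shown here, amino in place of hydrogen on an amide-type nitrogen is the first change that can be read in one place, and it gives a number 14.4 percentage points higher from compound 1 to compound 3 (beyond the scatter) as a modest rise beyond the scatter. This nitrogen of the core of compound 1 is therefore a place where one added heavy atom moves the inhibition read at the tested concentration.

The compounds shown leave open whether a methyl or a longer chain such as aminoethyl on the same nitrogen would move the number the same way. No measured evidence bears on why the step occurs.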